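The compounds below may be only part of what the source reports. "The series", "measured", "known", "first", "only" and "open" are said of these compounds alone.

In an in vivo ADME assay on the whole organism (strain Sprague-Dawley) for metabolic stability, with Rattus norvegicus as the target (a higher number here means that the compound lasts longer, a lower number that the compound disappears faster), compound 1 `O=C1[C@@H](NS(=O)(=O)c2ccc3c(Cl)c[nH]c3c2)CCN1c1ccc2c(c1)CCNC2` gives 6.3 h, compound 2 `O=C1[C@@H](NS(=O)(=O)c2ccc3cc[nH]c3c2)CCN1c1ccc2c(c1)CCNC2` gives 6.1 h and compound 3 `O=C1[C@@H](NS(=O)(=O)c2ccc3c(Cl)c[nH]c3c2)CCN1c1ccc2c(c1F)CCNC2` gives 7.8 h. Compound 1 therefore stands within the scatter of both other compounds, and the three values form a tight group with no clear order among them.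

The next structure, compound 4 `O=C1[C@@H](NS(=O)(=O)c2ccc3c(Cl)c[nH]c3c2)CCN1c1cc2c(cc1F)CNCC2`, departs from compound 1 by one change: fluoro in place of hydrogen on an aromatic carbon. The new fluoro sits ortho to a large group, on a six-membered aromatic ring of carbon only that is part of a fused or bridged system of two rings.

For the measured compounds named here, two measured steps bear on this change. The closer one is a 1.2-fold higher number from compound 1 to compound 3 (0.09 log units; within the scatter), which is also fluoro in place of hydrogen on an aromatic carbon, although compound 3 does not carry the fluoro on the same carbon as compound 4. The other step, a 1.0-fold lower number from compound 1 to compound 2 (0.01 log units; within the scatter), replaces chloro with hydrogen at a different place and shows how little this assay has moved across this small group. Neither step leaves the scatter, so no step beyond the scatter is expected here, and any shift would most likely be slightly upward. The estimated step is a 1.1-fold higher number from compound 1 to compound 4 (0.04 log units; within the scatter). For compound 4 the expected half-life is 6.9 h, with an estimated range from 4.5 h to 10.5 h.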

Compound 4, half-life: 6.2 h
The estimate for compound 4 lay 1.1-fold (0.05 log units) above the measured number, within the range that was stated.
By their numbers in this assay, from the lowest: compounds 2, 4, 1 and 3 (each within the scatter of the next).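

In this assay, for the compounds shown here, fluoro in place of hydrogen on this aromatic carbon, ortho to a large group, gave a 1.0-fold lower number from compound 1 to compound 4 (0.01 log units; within the scatter), so the earlier result for fluoro at another carbon is no longer the only reading of this change. Set beside a 1.2-fold higher number from compound 1 to compound 3 (0.09 log units; within the scatter), it shows two placements of fluoro on the same six-membered aromatic ring of carbon only, neither of which takes the half-life beyond the scatter, and the small upward step seen for compound 3 does not recur for compound 4, although both steps are too small to separate the two placements. No measurement is available that would explain why this carbon tolerates the change without a visible shift in the number.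

The compounds shown leave open whether a different group on this carbon, such as methoxy, a nitrile or a primary amine, would move the number beyond the scatter. They also leave open whether fluoro at this carbon would behave the same way in the compound without chloro, or alongside a methyl group on the ring nitrogen of the core.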